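Pyrimidin-5-yl Replacing 3-Hydroxyphenyl on the Thioether Carbon

The compounds below may be only part of what the source reports. "The series", "measured", "known", "first", "only" and "open" are said of these compounds alone.

Compound 3 `CC(Sc1nc2c(cnn2C)c(=O)n1-c1ccccc1)c1cccc(O)c1` gives the lowest number of the three measured compounds in an assay on isolated protein for inhibition of aldehyde dehydrogenase 1A1 (Homo sapiens) (on this read-out higher numbers stand for weaker inhibition and lower numbers for stronger inhibition), at 130 nM. Compound 1 `COc1ccc(C(C)Sc2nc3c(cnn3C)c(=O)n2-c2ccccc2)cc1` gives 352 nM, and compound 2 `CC(Sc1nc2c(cnn2C)c(=O)n1-c1ccccc1)c1ccncc1` gives 451 nM; the steps of a 2.7-fold lower number from compound 1 to compound 3 (0.43 log units; beyond the scatter) and a 3.5-fold lower number from compound 2 to compound 3 (0.54 log units; beyond the scatter) both lie beyond the scatter, while a 1.3-fold higher number from compound 1 to compound 2 (0.11 log units; within the scatter) does not. Compound 4 `CC(Sc1nc2c(cnn2C)c(=O)n1-c1ccccc1)c1cncnc1` differs from compound 3 in one place: pyrimidin-5-yl in place of 3-hydroxyphenyl on a saturated chain carbon bound to a saturated chain carbon and a sulfur. The step from compound 2 to compound 3 bears most closely on this change, since it also exchanges a six-membered aromatic ring with nitrogen for 3-hydroxyphenyl, and the step to compound 4 runs the other way. A modest rise in this assay is therefore expected, a 3.5-fold higher number from compound 3 to compound 4 (0.54 log units; beyond the scatter), giving compound 4 an estimated 450 nM with a range from 200 nM to 1000 nM.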

Compound 4, half-maximal inhibitory concentration in the aldehyde dehydrogenase 1A1 assay: 94 nM
Compound 4: the middle estimate sits 4.8-fold (0.68 log units) above what was measured; measured number outside the range, below it.
By their numbers in the aldehyde dehydrogenase 1A1 assay, from the lowest: compounds 4 and 3 (each within the scatter of the next); then compounds 1 and 2 (each within the scatter of the next).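

At this place, on a saturated chain carbon bound to a saturated chain carbon and a sulfur, pyrimidin-5-yl matches 3-hydroxyphenyl in the aldehyde dehydrogenase 1A1 assay, with a 1.4-fold lower number from compound 3 to compound 4 (0.14 log units; within the scatter), so a ring with no hydrogen-bond donor serves as well here. Ring nitrogen alone does not set the number, as pyrimidin-5-yl and pyridin-4-yl part with a 4.8-fold lower number from compound 2 to compound 4 (0.68 log units; beyond the scatter), and the replacement of 4-methoxyphenyl gives a 3.7-fold lower number from compound 1 to compound 4 (0.57 log units; beyond the scatter). In a physicochemical assay for solubility, using the shake flask method, in phosphate buffer, with a stated time of 24 h, at pH 7.4 (a lower number here means a less soluble compound, a higher number a more soluble compound), compound 3 gives 21000 nM and compound 4 gives 264000 nM. The compounds shown leave open whether an amine on the pyrimidin-5-yl ring, or a morpholine in its place, would hold the number in the aldehyde dehydrogenase 1A1 assay.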